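Phenylsulfonyl to benzoyl on the amine nitrogen

The source may report more compounds than this note shows. Statements on the series, on what has been measured and on what is new or still open speak of the compounds shown alone.

In an ADME assay on Vero cells (Chlorocebus sabaeus) for cytotoxicity, read by MTT assay, with a stated time of 48 h (a lower number here means a stronger inhibitor, a higher number a weaker inhibitor), compound 3 (`O=c1cc(N2CCN(CC3CCC(NS(=O)(=O)c4ccccc4)CC3)CC2)sc2c([N+](=O)[O-])cc(C(F)(F)F)cc12`) gives > 64 ug/mL, which is a limit and not a number. Compound 1 (`Cc1cccc(C(=O)OC2CCC(CN3CCN(c4cc(=O)c5cc(C(F)(F)F)cc([N+](=O)[O-])c5s4)CC3)CC2)c1`) gives > 64 ug/mL, also a limit. Compound 2 (`O=C(OC1CCC(CN2CCN(c3cc(=O)c4cc(C(F)(F)F)cc([N+](=O)[O-])c4s3)CC2)CC1)C1CCC1`) gives > 64 ug/mL, again a limit. Going by the values given here, the whole series so far therefore stands at the limit of > 64 ug/mL in this assay, at which 3 of the 3 values shown sit, and compound 3 has no number to measure a change against.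

Compound 4 (`O=C(NC1CCC(CN2CCN(c3cc(=O)c4cc(C(F)(F)F)cc([N+](=O)[O-])c4s3)CC2)CC1)c1ccccc1`) carries benzoyl in place of phenylsulfonyl on an amine nitrogen.

Among the compounds with values here, three measured steps bear on this change. The closest two alter the same group on the saturated ring carbon: a step that the two limits leave unreadable from compound 1 to compound 3 and a step that the two limits leave unreadable from compound 2 to compound 3. The third is a step that the two limits leave unreadable from compound 1 to compound 2. None of them gives a size to carry over, so no step beyond the scatter and no direction is expected in this assay. The expected change is a step that the limit leaves unreadable from compound 3 to compound 4.

Compound 4 is estimated at 90 ug/mL, with an expected range of 45 ug/mL to 200 ug/mL, and a report as a limit is the likeliest outcome.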

Compound 4, half-maximal inhibitory concentration: 44.3 ug/mL
Compound 4: the middle estimate sits 2.0-fold (0.31 log units) above what was measured; measured number outside the range, below it.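

In this assay, going by these compounds alone, compound 4 gives 44.3 ug/mL, the only value in the set that is a number and not a limit. Benzoyl in place of phenylsulfonyl on the amine nitrogen now gives a readable step, an at least 1.4-fold lower number from compound 3 to compound 4 (0.15 log units; that floor lies within the scatter), and benzamido reads the same way against both other groups on the saturated ring carbon, with an at least 1.4-fold lower number from compound 2 to compound 4 (0.15 log units; that floor lies within the scatter) and an at least 1.4-fold lower number from compound 1 to compound 4 (0.15 log units; that floor lies within the scatter). All three steps are floors only, set by the limit at which the other compounds rest: the limit of > 64 ug/mL in this assay, at which 3 of the 4 values shown sit.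

From the compounds shown here alone, how far the values of compound 1, compound 2 and compound 3 lie beyond that limit stays open, and with it the true size of all three steps. Also open, going by these compounds, is whether an acetyl group or a methanesulfonyl group on the same amine nitrogen would give a number in this assay.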